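From 4-fluorophenyl to phenyl, starting at a limit

This account rests on a few compounds, and the source may have more. Where it says the series, first, only, none or still open, it means among the compounds named here.

Compound 1 (`CN1CCN(c2ccc(Nc3ncc4nc(Nc5ccccc5)n([C@@H]5CCNC5)c4n3)cc2)CC1`) gives "not determined" (no result reported) in a functional assay on NCI-H1975 cells (Homo sapiens) for antiproliferative activity, read by MTT assay, with a stated time of 72 h (a lower number here means a stronger inhibitor, a higher number a weaker inhibitor), and so offers no comparison. Compound 2 (`CN1CCN(c2ccc(Nc3ncc4nc(Nc5ccc(F)cc5)n([C@@H]5CCN(S(=O)(=O)C6CC6)C5)c4n3)cc2)CC1`) stands at > 10000 nM as a limit of the assay and not a number. Compound 3 (`CN1CCN(c2ccc(Nc3ncc4nc(Nc5ccccc5)n([C@@H]5CCN(S(=O)(=O)C6CC6)C5)c4n3)cc2)CC1`) carries hydrogen in place of fluoro on an aromatic carbon, para to a large group (hydrogen in place of fluoro on an aromatic carbon). Among the measured compounds shown here, no measured pair shows what this change does, so no shift beyond the usual scatter is expected in this assay for this pair. The estimated step (a number no higher from compound 2 to compound 3 (the limit leaves the size open)) is therefore small. Compound 3 is estimated at 10000 nM with an expected range from 3000 nM to 30000 nM in this measurement.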

Compound 3, half-maximal inhibitory concentration: 200 nM
For compound 3 the middle estimate is 50-fold (1.70 log units) above the measured one; the measured number lies below the stated range.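

Going from 4-fluorophenyl to phenyl in this assay gives an at least 50-fold lower number from compound 2 to compound 3 (1.69 log units; beyond the scatter) and alters nothing else in the molecule, so what sits on this one aromatic carbon matters a great deal for the read-out. The full size of the step stays unknown, since compound 2 stands at a limit and not a number: the limit of > 10000 nM in this assay, at which 1 of the 3 values shown sits.

As far as these compounds go, only fluoro and hydrogen appear at this position, so it remains open how a chlorine atom or a methoxy group there would read. From the compounds shown here alone, it also remains open whether the same change would have a similar effect on a different group at the ring nitrogen of the pyrrolidine.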